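The compounds below may be only part of what the source reports. "The series", "measured", "known", "first", "only" and "open" are said of these compounds alone.

Measured in a functional assay on PC-3 cells (Homo sapiens) for antiproliferative activity, read by MTT assay, with a stated time of 48 h; a higher number here means a weaker inhibitor, a lower number a stronger inhibitor:

Compound 1 `C#CC(C)OC(=O)c1ccc(C(CC)(CC)c2ccc(OCCC(O)(CC)CC)c(C)c2)n1CC`: 14800 nM
Compound 2 `CCC(C)C(NC(=O)c1ccc(C(CC)(CC)c2ccc(OCCC(O)(CC)CC)c(C)c2)n1CC)C(=O)O`: 13800 nM

Compound 2 stands level with compound 1, since the two values cannot be told apart within the scatter. The next compound to be tested is compound 3 `CCn1c(C(=O)N(C)CC(=O)O)ccc1C(CC)(CC)c1ccc(OCCC(O)(CC)CC)c(C)c1`, which keeps the shared core and changes only the group on the carbonyl carbon: (carboxymethyl)(methyl)amino in place of (1-carboxy-2-methylbutyl)amino on a carbonyl carbon. For the measured compounds named here, one measured step bears on this, and it concerns the same place: a 1.1-fold lower number from compound 1 to compound 2 (0.03 log units; within the scatter). On these data alone, with a single such step to go on, no shift beyond the scatter is expected in this assay, and the direction remains open. The estimated move is a 1.0-fold higher number from compound 2 to compound 3 (0.01 log units; within the scatter). The expected value for compound 3 is 14000 nM, with an estimated range from 6500 nM to 30000 nM.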

Compound 3, half-maximal inhibitory concentration: 2250 nM
For compound 3 the middle estimate is 6.2-fold (0.79 log units) above the measured one; measured number below the stated range.
By their numbers in this assay, from the lowest: compound 3; then compounds 2 and 1 (each within the scatter of the next).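

In this assay the group on the carbonyl carbon proves able to move the number beyond the scatter, which the first pair did not show: (carboxymethyl)(methyl)amino gives a 6.1-fold lower number from compound 2 to compound 3 (0.79 log units; beyond the scatter) and, against the (1-methylprop-2-yn-1-yl)oxy group, a 6.6-fold lower number from compound 1 to compound 3 (0.82 log units; beyond the scatter) here. A carboxy-bearing group alone does not account for this shift, since compound 2 also carries one yet stands level with compound 1. Nothing available here explains the shift.

The change from compound 2 to compound 3 adds a methyl on the nitrogen, removes the amide hydrogen and drops the 2-methylpropyl-type branch together, so the shown compounds cannot separate these contributions. On these data alone, it also remains open how a plain carboxymethylamino group, a longer chain before the carboxylic acid, or an amine in its place would read.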